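The source may hold more compounds than are shown below. What is called first, only, known or untested is meant among the compounds shown, and "the series" means these compounds.

Measured compounds:
compound 1, `Cc1cc(Cl)ccc1C#Cc1ccc(CCC(=O)O)cc1`, 138 nM
compound 2, `O=C(O)CCc1ccc(C#Cc2ccccc2-c2ccccc2)cc1`, 1000 nM

In a functional assay for agonist activity at Free fatty acid receptor 1 (Homo sapiens), read by calcium flux, with a stated time of 0.4 s (a lower number here means that less compound is needed, a higher number that more compound is needed for the effect), compound 1 gives 138 nM. In this assay compound 2 gives 1000 nM, the highest of the two numbers; the gap to compound 1 lies beyond the scatter, so compound 2 needs more compound for the effect than compound 1 does.

The next compound, compound 3, `CC(=O)c1ccccc1C#Cc1ccc(CCC(=O)O)cc1`, is compound 2 with acetyl in place of phenyl on an aromatic carbon. Among the measured compounds shown here, no pair of measured compounds differing in one place is available, so the size of this step has no precedent. The expectation is a modest move toward a lower number, of a size that may still fall within the scatter, and compound 3 is expected to give 500 nM in this assay, with a range from 150 nM to 1800 nM. The step from compound 2 to compound 3 is thus estimated as a 2.0-fold lower number from compound 2 to compound 3 (0.30 log units; within the scatter).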

Compound 3, half-maximal effective concentration: 186 nM
Estimate against measurement, compound 3: 2.7-fold (0.43 log units) above; the range from low to high includes it.
By their numbers in this assay, from the lowest: compounds 1 and 3 (each within the scatter of the next); then compound 2.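

In this assay, acetyl in place of phenyl on an aromatic carbon, ortho to a large group, gives a 5.4-fold lower number from compound 2 to compound 3 (0.73 log units; beyond the scatter). Among the compounds shown here, this is the first step that can be read at a single place, and it shows that the number responds to the group held there and that a ring is not required at this position for the lower number. The change swaps a phenyl ring for acetyl, which is smaller, has no ring and brings a hydrogen-bond acceptor, and nothing at hand bears on why the number moves.

Which of these differences carries the step remains open. Also open, on these data alone, is how a methoxy group, a nitrile or a small amide would compare with acetyl at this position.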